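The compounds below may be only part of what the source reports. "The series", "measured", "known", "first", "only" and "open" are said of these compounds alone.

Compound 3 `O=c1cc(Nc2ccccc2)cc(-c2ccccc2)o1` gives 0.13 uM in a functional assay on KB cells (Homo sapiens) for cytotoxicity, read by MTT assay, with a stated time of 72 h; on this read-out lower numbers stand for an effect already at smaller amounts and higher numbers for an effect only at larger amounts of compound. Among the two numbers measured, compound 3 stands lowest, its nearest neighbour being compound 1 `COc1ccc(Nc2cc(-c3ccccc3)oc(=O)c2)cc1`, which in this assay gives 0.16 uM; the gap between them, a 1.2-fold lower number from compound 1 to compound 3 (0.09 log units; within the scatter), lies within the scatter. Compound 2 `COc1ccc(Nc2cc(C)oc(=O)c2)cc1` in this assay gives only a limit of the assay, > 30 uM. Compound 4 `O=c1cc(Nc2ccc(Br)cc2)cc(-c2ccccc2)o1` differs from compound 3 by bromo in place of hydrogen on an aromatic carbon. Two measured steps exist. The change an at least 180-fold higher number from compound 1 to compound 2 (2.27 log units; beyond the scatter) is large, but it concerns another part of the molecule, the group attached to the shared core. The change a 1.2-fold lower number from compound 1 to compound 3 (0.09 log units; within the scatter) concerns the same ring that receives the new bromo, a group on the aromatic carbon para to a large group, and it stayed within the scatter. The expectation for this assay is therefore that exchanging hydrogen for bromo at that place alters little: compound 4 is expected to show a 1.2-fold higher number from compound 3 to compound 4 (0.06 log units; within the scatter), a step within the scatter. Compound 4 is accordingly estimated at 0.15 uM, within a range of 0.06 uM to 0.4 uM.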

Compound 4, concentration for half-maximal effect: 0.32 uM
Compound 4: the middle estimate sits 2.1-fold (0.33 log units) below what was measured, and the stated range covers the measured number.
By their numbers in this assay, from the lowest: compounds 3, 1 and 4 (each within the scatter of the next, the first and the last beyond it). At a limit, above all of these: compound 2.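

Up to this point, the only change seen on an aromatic carbon para to a large group was hydrogen for methoxy, and it stayed within the scatter. In this assay, among the compounds shown here, bromo in place of hydrogen now gives a 2.5-fold higher number from compound 3 to compound 4 (0.39 log units; beyond the scatter), the first step at this place that can be told apart from noise, though only a modest one. Bromo in place of methoxy gives a 2.0-fold higher number from compound 1 to compound 4 (0.30 log units; within the scatter), so these two groups cannot be separated here, and even the step from hydrogen is small beside an at least 180-fold higher number from compound 1 to compound 2 (2.27 log units; beyond the scatter), where methyl replaces phenyl elsewhere on the molecule.

The compounds shown leave open how this place responds to quite different groups, such as an amine or a carboxylic acid, and whether a larger group here would move the number further. Nothing measured in this set bears on why bromo shifts the number at this place.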